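The source may hold more compounds than are shown below. What is called first, only, known or untested is meant among the compounds shown, and "the series" means these compounds.

Measured so far in a functional assay on the whole organism for inhibition, with Rattus norvegicus as the target, read by paw edema; on this read-out higher numbers stand for an effect only at larger amounts of compound and lower numbers for an effect already at smaller amounts

- compound 1 `O=C(O)c1cc(-c2c[nH]cn2)ccc1O` gives 100 mg/kg
- compound 2 `O=C(O)c1ccc(-c2cscn2)cc1O` gives 70 mg/kg

Compound 1 at 100 mg/kg and compound 2 at 70 mg/kg lie within the usual scatter of each other, so these two numbers do not separate them. For the measured compounds named here, the two compounds differ in more than one place, and the series therefore offers no measured single-change step to work from.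

Compound 3 `O=C(O)c1cc(-n2ccnc2)ccc1O` has not yet been measured. It carries 1H-imidazol-1-yl in place of 1H-imidazol-4-yl of compound 1 on an aromatic carbon, meta to a carboxy group and para to a hydroxy group 1H-imidazol-1-yl in place of 1H-imidazol-4-yl on an aromatic carbon and so holds the same atoms joined differently.

The expected change is a 1.3-fold lower number from compound 1 to compound 3 (0.10 log units; within the scatter) and lies within the scatter, so no real shift in either direction is foreseen. The only anchors for this expectation are compound 1 at 100 mg/kg and compound 2 at 70 mg/kg and the range is kept wide for that reason. For compound 3 the estimated value is 80 mg/kg with an expected range from 30 mg/kg to 200 mg/kg on this basis.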

Compound 3, dose for half-maximal effect: 75 mg/kg
For compound 3 the middle estimate is 1.1-fold (0.03 log units) above the measured one, within the range that was stated.
By their numbers in this assay, from the lowest: compounds 2, 3 and 1 (each within the scatter of the next).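

For the compounds shown here, at the aromatic carbon meta to a carboxy group and para to a hydroxy group, 1H-imidazol-1-yl in place of 1H-imidazol-4-yl gives a 1.3-fold lower number from compound 1 to compound 3 (0.12 log units; within the scatter) in this assay, the first single-change step. The exchange keeps the same atoms but joins them differently, going from 1 hydrogen-bond donor and 1 hydrogen-bond acceptor in the leaving group to 0 hydrogen-bond donors and 2 hydrogen-bond acceptors in the entering one, and the paw edema read-out does not separate the two compounds. No measured data at hand bear on the origin of this result.

The compounds shown leave open whether a group of another kind on this carbon, such as an aminomethyl group or a phenyl ring, would give a step beyond the scatter. Also open, going by these compounds, is what the carboxy group of the core of compound 1 contributes, which a methyl ester in its place would address, since this single step concerns only the imidazolyl attachment.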